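The source may report more compounds than this note shows. Statements on the series, on what has been measured and on what is new or still open speak of the compounds shown alone.

Compound 1 `O=S(=O)(NCCCNCc1ccccc1Cl)c1cc(C(F)(F)F)cc(C(F)(F)F)c1` is tested in a functional assay on A2780 cells (Homo sapiens) for inhibition, read by MTT assay, with a stated time of 72 h (on this read-out lower numbers stand for stronger inhibition of growth and higher numbers for weaker inhibition of growth), and gives 9300 nM. Compound 2 `O=S(=O)(NCCCNCc1ccc(Cl)c(C(F)(F)F)c1)c1cc(C(F)(F)F)cc(C(F)(F)F)c1` differs from it only in the aromatic group attached to the saturated chain carbon bound to an amine nitrogen, and in this assay compound 2 gives 5900 nM. Among the compounds with values here, the step of a 1.6-fold lower number from compound 1 to compound 2 (0.20 log units; within the scatter) is within the scatter, so the two numbers cannot be told apart with confidence; compound 2 stands at the smaller of the two measured numbers, with compound 1 as its only neighbour.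

Compound 3 `O=S(=O)(NCCCNCc1ccc(C(F)(F)F)cc1)c1cc(C(F)(F)F)cc(C(F)(F)F)c1` has not been measured. It differs from compound 2 in one place: 4-(trifluoromethyl)phenyl in place of 4-chloro-3-(trifluoromethyl)phenyl on a saturated chain carbon bound to an amine nitrogen. Within the data shown here, only one measured step touches this position, the step of a 1.6-fold lower number from compound 1 to compound 2 (0.20 log units; within the scatter), and it did not leave the scatter even though the aromatic group changed more. A chlorine leaving the ring is therefore expected to move the number by little or nothing beyond the scatter, and the estimated step from compound 2 to compound 3 is a 1.3-fold higher number from compound 2 to compound 3 (0.10 log units; within the scatter). In this assay compound 3 is expected to give about 7500 nM, with a likely range from 3500 nM to 16000 nM.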

Compound 3, concentration for 50% growth inhibition: 2800 nM
Estimate against measurement, compound 3: 2.7-fold (0.43 log units) above, and the stated range ends above it.
By their numbers in this assay, from the lowest: compound 3; then compounds 2 and 1 (each within the scatter of the next).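

In this assay, the aromatic group on the saturated chain carbon bound to an amine nitrogen now proves able to move the number beyond the scatter: the change to 4-(trifluoromethyl)phenyl gives a 2.1-fold lower number from compound 2 to compound 3 (0.32 log units; beyond the scatter), and set against 2-chlorophenyl it gives a 3.3-fold lower number from compound 1 to compound 3 (0.52 log units; beyond the scatter). Both steps are modest, but together they place compound 3 lowest of the three, whereas the two earlier compounds could not be told apart. The step from compound 2 to compound 3 is also more than the loss of a chlorine, as the names show: 4-(trifluoromethyl)phenyl is not simply 4-chloro-3-(trifluoromethyl)phenyl minus that atom, and nothing measured here explains why this group gives the lowest number.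

The compounds shown cannot separate the contribution of the trifluoromethyl group from that of its place on the ring, a question that plain phenyl, 4-chlorophenyl and 3-(trifluoromethyl)phenyl would address. They also leave open how a pyridine ring or a saturated cyclohexyl group would behave at this position, and whether a longer chain would change the picture.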